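A few compounds are considered here, and "the series" means these few. Any claim that something is new, unique, unknown or untested is made for them only; others in the source may bear on it.

For the measured compounds named here, compound 2 `COc1cc2cc(NC(C)=O)c(=O)oc2cc1OCCCOc1no[n+]([O-])c1S(=O)(=O)c1ccccc1` gives 88.5% in a functional assay on MCF7 cells (Homo sapiens) for inhibition, read by MTT assay, with a stated time of 48 h, tested at 10 uM; a lower number here means less inhibition, a higher number more inhibition at the concentration tested (going by the name of the read-out); the only other measured compound, compound 1 `COc1cc2ccc(=O)oc2cc1OCCCOc1no[n+]([O-])c1S(=O)(=O)c1ccccc1`, sits at 88.6%, within the scatter of it. Going by the values given here, the one measured step, a number 0.1 percentage points lower from compound 1 to compound 2 (within the scatter), shows that adding acetamido in place of hydrogen moved nothing beyond the scatter. Among the compounds with values here, compound 3 `COc1cc2cc(N)c(=O)oc2cc1OCCCOc1no[n+]([O-])c1S(=O)(=O)c1ccccc1` differs from compound 2 by hydrogen in place of acetyl on a nitrogen on an aromatic ring, a change no measured pair covers directly; the single step available bears on it only loosely and was flat. Compound 3 is therefore expected to stay level with compound 2, a number 0.5 percentage points lower from compound 2 to compound 3 (within the scatter), and is estimated at 88%, range 78% to 95%.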

Compound 3, a percentage reported as inhibition, at one concentration (the size of the read-out at that concentration, not a potency): 91.6%
Estimate against measurement, compound 3: 3.6 percentage points below; the range from low to high includes it.
By their numbers in this assay, from the lowest: compounds 2, 1 and 3 (each within the scatter of the next).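

Replacing acetyl with hydrogen on the nitrogen on an aromatic ring gives, in this assay, a step of a number 3.1 percentage points higher from compound 2 to compound 3 (within the scatter), and amino in place of hydrogen on an aromatic carbon gives a number 3 percentage points higher from compound 1 to compound 3 (within the scatter). The free amino group thus joins hydrogen and acetamido at this position with no difference beyond the scatter at this single concentration. Nothing available accounts for these readings.

Open, as far as these compounds go, is whether a dimethylamino group or a carboxylic acid at this position would stay level. Also open, from the compounds shown here alone, is whether the three compounds would separate at lower concentrations.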